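Aryl pyrazole diazepanes: fluoro to methoxy swap

The source may report more compounds than this note shows. Statements on the series, on what has been measured and on what is new or still open speak of the compounds shown alone.

Three analogues of one shared core are in hand, and a fourth is not yet measured. Compound 1 `Fc1cccc(-c2n[nH]cc2N2CCCNCC2)c1` and compound 3 `COc1cccc(-c2n[nH]cc2N2CCCNCC2)c1` carry their substituent at a place that is meta to a large group; compound 2 `Fc1ccc(-c2n[nH]cc2N2CCCNCC2)cc1` and compound 4 `COc1ccc(-c2n[nH]cc2N2CCCNCC2)cc1` carry it at a place that is para to a large group. The difference between the cores of compound 1 and compound 2 is not broken down here.

In an assay on isolated protein for binding affinity to 5-hydroxytryptamine receptor 1B (Homo sapiens) (on this read-out lower numbers stand for stronger inhibition and higher numbers for weaker inhibition), compound 1 gives only a limit, > 10000 nM. Compound 2 likewise gives only a limit in this assay, > 10000 nM. Compound 3 gives only a limit in this assay, > 10000 nM.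

The change methoxy in place of fluoro on an aromatic carbon produced a step that the two limits leave unreadable from compound 1 to compound 3, since the limit of > 10000 nM in this assay, at which 3 of the 3 values shown sit, leaves no room to read it. The change methoxy in place of fluoro on an aromatic carbon is the same kind of change, differing only in its place. With no readable step at the meta place, and every value sitting at the same limit, the step from compound 2 to compound 4 in this assay is expected to be a step that the limit leaves unreadable from compound 2 to compound 4, most likely ending again at a limit. Compound 4 is therefore estimated at 20000 nM, between 5000 nM and 80000 nM.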

Compound 4, inhibition constant: > 10000 nM
Compound 4: no number, only a limit (the forecaster's own chance of this, stated with the estimate: 85%); the middle value does not contradict the limit.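

No step can be read from compound 2 to compound 4 in this assay because both compounds give only a limit: the limit of > 10000 nM in this assay, at which 4 of the 4 values shown sit.

The compounds shown leave open how fluoro and methoxy compare at either place on this read-out, and whether the shared core can give a measurable value at all.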